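The compounds below may be only part of what the source reports. "The series", "measured", "known", "first", "only" and "open" are said of these compounds alone.

Measured compounds:
compound 1 `Cc1oc(-c2c(Br)cccc2Br)nc1CN1CCC(C(=O)NCCCN2C[C@H](C)C[C@H](C)C2)CC1`: 6500 nM
compound 2 `Cc1ccccc1-c1nc(CN2CCC(C(=O)N3CCN(CCN(C)C)CC3)CC2)c(C)o1`: 27200 nM

In an ADME assay on Huh7.5.1 cells (Homo sapiens) for cytotoxicity, read by ATP content, with a stated time of 48 h (a higher number here means that more compound is tolerated, a lower number that less compound is tolerated), compound 1 gives 6500 nM, the lowest of the two numbers recorded. Compound 2, the nearest, gives 27200 nM, and that gap lies beyond the scatter. Compound 3 `Cc1ccc(-c2nc(CN3CCC(C(=O)NCCCN4C[C@H](C)C[C@H](C)C4)CC3)c(C)o2)cc1C` is not yet measured. It differs from compound 1 in one place: 3,4-dimethylphenyl in place of 2,6-dibromophenyl on an aromatic carbon. Going by the values given here, the two measured compounds differ from each other in more than one place, so no step for this kind of change is available from this set. The expectation for this assay is a small move upward, of a size that may not clear the scatter, leaning only on the point that compound 2, which also lacks the 2,6-dibromophenyl group, is tolerated at 27200 nM. The estimated step from compound 1 to compound 3 is a 1.5-fold higher number from compound 1 to compound 3 (0.19 log units; within the scatter). Compound 3 is expected at 10000 nM, within a range of 4000 nM to 30000 nM.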

Compound 3, half-maximal cytotoxic concentration: 6910 nM
Beside the measured number, compound 3's estimate is 1.4-fold (0.16 log units) above it; the measured number falls inside the stated range.
By their numbers in this assay, from the lowest: compounds 1 and 3 (each within the scatter of the next); then compound 2.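

Going by these compounds alone, compound 1 and compound 3 give the first single-change reading at this aromatic carbon, next to the ring nitrogen and the ring oxygen of the core. In this assay, 3,4-dimethylphenyl in place of 2,6-dibromophenyl gives a 1.1-fold higher number from compound 1 to compound 3 (0.03 log units; within the scatter) and so does not separate the two compounds. At this position, with the rest of the molecule held constant, the two bromine atoms are not required for a reading at this level, and no measurement in hand explains the result.

On these data alone, whether an amine or a carboxylic acid on the phenyl ring would shift the reading remains open. Compound 2, at 27200 nM, differs from compound 1 in more than one place, so its number cannot be assigned to any single part of the structure.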